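The source may report more compounds than this note shows. Statements on the series, on what has been measured and on what is new or still open speak of the compounds shown alone.

Measured so far:
- compound 1 `Cc1ccc(S(=O)(=O)c2nc3ccccc3nc2N2CCc3ccccc3C2)cc1` gives 22400 nM in a functional assay on PC-3 cells (Homo sapiens) for cytotoxicity, read by MTT assay, with a stated time of 72 h; a higher number here means a weaker inhibitor, a lower number a stronger inhibitor
- compound 2 `O=S(=O)(c1ccccc1)c1nc2ccccc2nc1N1CCCC(O)C1` gives 2100 nM in this assay

Two compounds only, and they differ in more than one place, so no single-change step can be read between them; their two values show compound 2 with the lower number of the pair, compound 1 clearly higher, the gap beyond the scatter. Compound 2 is therefore the stronger inhibitor of the two on the numbers at hand.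

Compound 3 `Cc1ccc(S(=O)(=O)c2nc3ccccc3nc2N2CCCC(O)C2)cc1` is not yet measured in this assay. It keeps the hydroxypiperidine of compound 2 and carries the change (methyl in place of hydrogen on an aromatic carbon), that is, methyl in place of hydrogen on an aromatic carbon, para to a large group; read one bond further out, phenyl becomes 4-methylphenyl. The same 4-methylphenyl sulfone is present in compound 1, but compound 1 also carries a different amine, so its value cannot be assigned to the methyl alone. Going by the values given here, with no single-change step available, the expectation is a step of no size beyond the scatter, leaning slightly to a higher number. Compound 3 is accordingly expected to give 2800 nM with a range of 1000 nM to 8000 nM in this assay, which means an expected step of a 1.3-fold higher number from compound 2 to compound 3 (0.12 log units; within the scatter).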

Compound 3, half-maximal inhibitory concentration: 5330 nM
Compound 3: middle estimate off by 1.9-fold (0.28 log units), on the low side; low and high end bracket the measured number.
By their numbers in this assay, from the lowest: compound 2; then compound 3; then compound 1.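

In this assay, going by these compounds alone, methyl in place of hydrogen on an aromatic carbon, para to a large group, gives a 2.5-fold higher number from compound 2 to compound 3 (0.40 log units; beyond the scatter), the first single-change reading at this position, and phenyl to 4-methylphenyl moves the number beyond the scatter in the weaker direction. With the 4-methylphenyl held constant, 3-hydroxypiperidin-1-yl in place of 1,2,3,4-tetrahydroisoquinolin-2-yl gives a 4.2-fold lower number from compound 1 to compound 3 (0.62 log units; beyond the scatter), so the amine change can now be read apart from the methyl, and the difference seen earlier between compound 1 and compound 2 is resolved into two single-change steps, each modest and each beyond the scatter. No measurement is at hand that accounts for either step.

Going by these compounds, whether the effect belongs to methyl alone or extends to other groups at this position, such as methoxy, chloro or a carboxylic acid, remains open. Also open, on these data alone, is what the hydroxyl itself contributes, which a plain piperidine or an open-chain amine on the same core would address, and whether the amine step holds when the phenyl carries no methyl.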